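This account rests on a few compounds, and the source may have more. Where it says the series, first, only, none or still open, it means among the compounds named here.

Working notes on the series. The compounds share one core and differ in the group carried on a nitrogen on an aromatic ring. Compound 1 `COc1cc(Nc2ncc(C(F)(F)F)c(N3Cc4cccc(N(C)S(C)(=O)=O)c4C3)n2)cc(OC)c1`, compound 2 `CC(=O)N1CCN(c2ccc(Nc3ncc(C(F)(F)F)c(N4Cc5cccc(N(C)S(C)(=O)=O)c5C4)n3)cc2)CC1` and compound 3 `CN(c1cccc2c1CN(c1nc(Nc3cccc(Oc4ccccc4)c3)ncc1C(F)(F)F)C2)S(C)(=O)=O` have each been run in a functional assay on U-87MG ATCC cells for antiproliferative activity against U-87 MG (Homo sapiens), read by spectrophotometry, with a stated time of 2 days; on this read-out lower numbers stand for stronger inhibition of growth and higher numbers for weaker inhibition of growth. For compound 1 the read-out is a limit of the assay, > 30000 nM, and not a number. Compound 2 gives 22100 nM in this assay, and compound 3 gives 19500 nM; these two sit within the usual scatter of each other, so no order between them is drawn. Compound 1 stands at the limit of > 30000 nM in this assay, at which 1 of the 3 values shown sits, so its place against compound 2 and compound 3 cannot be told from the values shown.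

Compound 4 `Cc1ccc(Nc2ncc(C(F)(F)F)c(N3Cc4cccc(N(C)S(C)(=O)=O)c4C3)n2)c(C)c1` is not yet measured. It differs from compound 1 by 2,4-dimethylphenyl in place of 3,5-dimethoxyphenyl on a nitrogen on an aromatic ring. For the measured compounds named here, no step between measured compounds is known, and all three values so far are weak. Compound 4 is expected to stay in that weak region, with the step of an at least 1.2-fold lower number from compound 1 to compound 4 (0.07 log units; that floor lies within the scatter) expected to be none beyond the scatter. The estimate for compound 4 in this assay is 25000 nM, in the range 8000 nM to 60000 nM, with a fair chance that only a limit is reported again.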

Compound 4, concentration for 50% growth inhibition: > 30000 nM
Compound 4 ended at the assay's limit (the forecaster's own chance of this, stated with the estimate: 40%); at least 1.2-fold (0.07 log units) between middle value and limit.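

In this assay compound 4 gives > 30000 nM, a limit of the assay and not a number. Compound 1 also stands at a limit, so no step from compound 1 to compound 4 can be read: the limit of > 30000 nM in this assay, at which 2 of the 4 values shown sit.

From the compounds shown here alone, whether 2,4-dimethylphenyl in place of 3,5-dimethoxyphenyl changes growth inhibition at all stays open.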